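Fluoro for Ethoxy on the Urea-Linked Phenyl Ring

This account rests on a few compounds, and the source may have more. Where it says the series, first, only, none or still open, it means among the compounds named here.

Compound 1 `Cc1ccccc1NC(=O)Nc1cc(C(C)(C)C)nn1-c1ccccc1` gives 1.2 degrees C in an assay on isolated protein for inhibition of Ephrin type-A receptor 2 (Homo sapiens), read by thermal shift assay, tested at 10 uM; on this read-out lower numbers stand for weaker stabilisation of the target and higher numbers for stronger stabilisation of the target against heat.
Compound 2 `CCOc1ccc(NC(=O)Nc2cc(C(C)(C)C)nn2-c2ccccc2)cc1` gives 1 degrees C in this assay.

Going by the values given here, compound 2 carries the lower of the two numbers, but the only measured step, a number 0.20 degrees C lower from compound 1 to compound 2 (within the scatter), lies within the scatter, so the two compounds cannot be told apart on this read-out.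

Compound 3 `CC(C)(C)c1cc(NC(=O)Nc2ccc(F)cc2)n(-c2ccccc2)n1` is the next compound. Compared with compound 2 it shows (fluoro in place of ethoxy on an aromatic carbon). Among the compounds with values here, the single measured step, a number 0.20 degrees C lower from compound 1 to compound 2 (within the scatter), also changed what sits on that aromatic ring and produced no movement beyond the scatter. Fluoro against ethoxy is itself untested, and one step is thin ground. Still, nothing measured points in either direction, so the step from compound 2 to compound 3 is expected to be no change at the digits printed from compound 2 to compound 3 (within the scatter), within the scatter. Compound 3 is therefore estimated at 1 degrees C, with a range from 0 degrees C to 2 degrees C.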

Compound 3, shift of the target's melting temperature: -2.2 degrees C
Compound 3: middle estimate off by 3.2 degrees C, on the high side, and the stated range ends above it.
By their numbers in this assay, from the lowest: compound 3; then compounds 2 and 1 (each within the scatter of the next).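

Going by these compounds alone, putting fluoro in place of ethoxy on this aromatic carbon gives a number 3.2 degrees C lower from compound 2 to compound 3 (beyond the scatter) in this assay so the group held here can move the read-out, which the one earlier step could not show. The 4-fluorophenyl group also stands apart from the 2-methylphenyl group, with a number 3.4 degrees C lower from compound 1 to compound 3 (beyond the scatter) and compound 3 at -2.2 degrees C is the only one of the three with a negative shift. Nothing available explains why this change lowers the number.

The compounds shown leave open whether the drop follows from fluoro arriving or from ethoxy leaving. A plain hydrogen, a methoxy group or an amine on the same carbon would help separate those two readings.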